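A few compounds are considered here, and "the series" means these few. Any claim that something is new, unique, unknown or untested is made for them only; others in the source may bear on it.

Measured so far:
compound 1, `CC(C)CNc1nnc(SCC(=O)N(Cc2cccc([N+](=O)[O-])c2)c2ccc(F)cc2)s1`, 17.3% in an assay on isolated protein for inhibition of Amine oxidase [flavin-containing] A (Homo sapiens), read by fluorescence and Amplex Red, with a stated time of 30 min, tested at 1 nM; a higher number here means a stronger effect of the compound at the concentration tested, a lower number a weaker effect
compound 2, `CC(C)Nc1nnc(SCC(=O)N(Cc2cccc([N+](=O)[O-])c2)c2ccc(F)cc2)s1`, 13.6% in this assay

Compound 2 and compound 1 lie within the usual scatter of each other, as the step of a number 3.7 percentage points lower from compound 1 to compound 2 (within the scatter) shows, so neither stands apart from the other on these two numbers. Compound 3, `CCNc1nnc(SCC(=O)N(Cc2cccc([N+](=O)[O-])c2)c2ccc(F)cc2)s1`, differs from compound 2 by hydrogen in place of methyl on a saturated chain carbon bound to a nitrogen on an aromatic ring and a saturated chain carbon, that is, isopropylamino becomes ethylamino. Going by the values given here, the one measured step that bears on this is the earlier shortening of the same chain, a number 3.7 percentage points lower from compound 1 to compound 2 (within the scatter), which stayed within the scatter. A further shortening of that chain is therefore expected to move this assay by no more than the scatter and in no particular direction, so the step of a number 1.6 percentage points lower from compound 2 to compound 3 (within the scatter) is expected to be small. Compound 3 is estimated at 12%, within a range from 2% to 24%.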

Compound 3, a percentage reported as inhibition, at one concentration (the size of the read-out at that concentration, not a potency): 21%
Compound 3: the middle estimate sits 9 percentage points below what was measured; low and high end bracket the measured number.
By their numbers in this assay, from the lowest: compounds 2, 1 and 3 (each within the scatter of the next).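

In this assay, going from isopropylamino to ethylamino gives a number 7.4 percentage points higher from compound 2 to compound 3 (within the scatter), and going from isobutylamino to ethylamino gives a number 3.7 percentage points higher from compound 1 to compound 3 (within the scatter). Isobutyl, isopropyl and ethyl on this nitrogen therefore cannot be told apart here, so even the larger shortening of the chain, from isobutyl to ethyl, shows no trend in either direction. Nothing on hand speaks to why these three numbers fall as they do.

Still open, from the compounds shown here alone, is whether a group of a different kind at this place, such as a plain amino group, a longer chain like hexyl or a cyclohexyl ring, would move the number beyond the scatter. Also open, going by these compounds, is whether these three compounds would separate at other concentrations, since a reading at one concentration is not a potency.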